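The compounds below may be only part of what the source reports. "The series", "measured", "known", "first", "only" and "open" are said of these compounds alone.

Measured so far:
Compound 1, `C[C@H](NC(=O)CN(c1nc(Cl)nc2[nH]cnc12)C1CC1)C(=O)O`: in a functional assay on the whole organism (Tail, strain ICR) with Mus musculus as the target, in the tail flick test, with a stated time of 90 min, at a dose of 25 umol/kg by the oral route (on this read-out lower numbers stand for a weaker effect and higher numbers for a stronger effect at the one dose given), compound 1 gives 43.5%.
Compound 2, `O=C(CN(c1nc(Cl)nc2[nH]cnc12)C1CC1)NCC(=O)OCc1ccccc1`: in this assay compound 2 gives 27.2%.
Compound 3, `O=C(O)CC[C@H](NC(=O)CN(c1nc(Cl)nc2[nH]cnc12)C1CC1)C(=O)O`: in this assay compound 3 gives 44.7%.

Compound 3 holds the highest of the three numbers, but its gap to compound 1 lies within the scatter of repeated measurements, so the two cannot be told apart; only compound 2 sits clearly lower. The unmeasured compound 4, `CSCC[C@H](NC(=O)CN(c1nc(Cl)nc2[nH]cnc12)C1CC1)C(=O)O`, differs from compound 3 in a single place: methylsulfanyl in place of carboxy on a saturated chain carbon, three bonds along the chain from an amide-type nitrogen and a carbonyl carbon. Going by the values given here, one measured step bears on this part of the structure: a number 1.2 percentage points higher from compound 1 to compound 3 (within the scatter). That step, which grew the chain by a carboxymethyl group, left the read-out essentially where it was, a hint that this part of the molecule tolerates change, although a single step is thin evidence. Compound 2 shows a lower value but differs from the others in more than one place, so it gives no direct guide to the swap of a carboxy for a methylsulfanyl. No step beyond the scatter is therefore expected for compound 4: a number 2.7 percentage points lower from compound 3 to compound 4 (within the scatter). Compound 4 is estimated at 42%, with a range from 28% to 56%.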

Compound 4, a percentage reported as activity, at one dose (the size of the read-out at that dose, not a potency): 14%
Estimate against measurement, compound 4: 28 percentage points above; the whole stated range lies above it.
By their numbers in this assay, from the lowest: compound 4; then compound 2; then compounds 1 and 3 (each within the scatter of the next).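

This position is less forgiving than compound 3 alone suggested: in this assay, methylsulfanyl in place of carboxy gives a number 30.7 percentage points lower from compound 3 to compound 4 (beyond the scatter) and so separates two side chains that differ by only a few atoms. Measured from the shorter side chain of compound 1, (methylsulfanyl)methyl in place of hydrogen gives a number 29.5 percentage points lower from compound 1 to compound 4 (beyond the scatter) while carboxymethyl on the same carbon gives a number 1.2 percentage points higher from compound 1 to compound 3 (within the scatter) in the same assay, so among these compounds the outcome depends on which group enters, and adding to the chain does not by itself set the result. The swap removes the hydrogen-bond donor and both oxygen atoms of the carboxy group and brings in a sulfur atom, but nothing measured here explains the drop.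

On these data alone, it remains open whether the lower number reflects the loss of the carboxy group or the presence of the sulfur, and a sulfur-free 2-methylpropyl or butyl chain at this place would help to tell these apart. As far as these compounds go, how an amine, a hydroxyl or a primary amide at the end of the same chain would compare also remains open.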